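Amide series: side-chain amine variation and cell growth inhibition

The source may hold more compounds than are shown below. What is called first, only, known or untested is meant among the compounds shown, and "the series" means these compounds.

Compound 1 `CCN(CC)CCNc1cc(C)c2cc(NC(=O)c3ccc(Cl)c(Cl)c3)ccc2n1`: in a functional assay on SK-BR-3 cells (Homo sapiens) for antiproliferative activity, read by MTT assay, with a stated time of 72 h (on this read-out lower numbers stand for stronger inhibition and higher numbers for weaker inhibition), compound 1 gives 3710 nM.
Compound 2 `Cc1cc(N(C)C)nc2ccc(NC(=O)c3ccc(Cl)c(Cl)c3)cc12`: in this assay compound 2 reaches only a limit, > 50000 nM.
Compound 3 `CCN1CCN(c2cc(C)c3cc(NC(=O)c4ccccc4Cl)ccc3n2)CC1`: in this assay compound 3 also reaches only a limit, > 50000 nM.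

Compound 2 therefore stands at the limit of > 50000 nM in this assay, at which 2 of the 3 values shown sit, with no number of its own. Among the measured compounds shown here, the one measured step that bears on the next change is an at least 13-fold higher number from compound 1 to compound 2 (1.12 log units; beyond the scatter), a large loss on replacing the (2-(diethylamino)ethyl)amino chain by dimethylamino. Compound 4 `Cc1cc(NCCN2CCCC2)nc2ccc(NC(=O)c3ccc(Cl)c(Cl)c3)cc12` reverses that kind of change: (2-(pyrrolidin-1-yl)ethyl)amino in place of dimethylamino on an aromatic carbon. Since the chain entering resembles the one whose removal gave an at least 13-fold higher number from compound 1 to compound 2 (1.12 log units; beyond the scatter), a large step back downward is expected, toward the region of compound 1. Compound 4 is expected near 4500 nM, in a range of 1500 nM to 15000 nM, which would mean an expected step of an at least 11-fold lower number from compound 2 to compound 4 (1.04 log units; beyond the scatter).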

Compound 4, half-maximal inhibitory concentration: 9530 nM
Estimate against measurement, compound 4: 2.1-fold (0.33 log units) below; low and high end bracket the measured number.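

In this assay, the (2-(pyrrolidin-1-yl)ethyl)amino chain on this aromatic carbon, next to the ring nitrogen, brings back a measurable value: an at least 5.2-fold lower number from compound 2 to compound 4 (0.71 log units; beyond the scatter). That step rests on a limit, not a number, for compound 2: the limit of > 50000 nM in this assay, at which 2 of the 4 values shown sit. The chain end also counts, as pyrrolidin-1-yl does not fully match diethylamino: a 2.6-fold higher number from compound 1 to compound 4 (0.41 log units; beyond the scatter).

Still open, as far as these compounds go, is how a morpholin-4-yl chain end or a longer chain of three carbons between the two nitrogens would fare on the shared core. Compound 3 differs from the others in more than one place, so it settles nothing about this chain.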